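The source may hold more compounds than are shown below. What is called first, only, known or untested is meant among the compounds shown, and "the series" means these compounds.

Compound 1 `CC(C)c1cccc2nc(N3CCN(C)CC3)oc12` is one of three compounds built on a shared core and tested in a functional assay on ileum (strain Hartley) for agonist activity at 5-hydroxytryptamine receptor 3A (Cavia porcellus); on this read-out higher numbers stand for higher potency (the scale is a negative logarithm) and lower numbers for lower potency. In this assay compound 1 gives < 4, which is a limit of the assay and not a number. Compound 3 `CCc1ccc2oc(N3CCN(C)CC3)nc2c1` in this assay likewise gives < 4, again only a limit. Within the data shown here, compound 2 `Cc1cc(Cl)cc2nc(N3CCN(C)CC3)oc12` is the one compound with a figure: in this assay compound 2 gives 6.7. Compound 1 therefore stands at the limit of < 4 in this assay, at which 2 of the 3 values shown sit, with no number of its own to place it against compound 2.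

Compound 4 `COc1cccc2nc(N3CCN(C)CC3)oc12` differs from compound 1 by a single change: methoxy in place of isopropyl on an aromatic carbon. The methoxy enters on an aromatic carbon of a six-membered aromatic ring of carbon only, part of a fused system of two rings, ortho to a fused ring. Among the measured compounds shown here, no pair of measured compounds isolates this change, so what follows is an expectation only. Compound 4 is expected to gain in this assay by a number at least 1.00 log units higher from compound 1 to compound 4 (beyond the scatter), a step that would exceed the scatter, though a limit for compound 4 remains possible. The estimate for compound 4 in this assay is 5, within 4 to 6.3.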

Compound 4, negative logarithm of the half-maximal effective concentration: < 4
Compound 4: only a limit was reported; the forecaster's own chance of this, stated with the estimate: 35%; middle value at least 1.00 log units away from the limit.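

In this assay compound 4 gives < 4, which is a limit of the assay and not a number. Compound 1 also has only a limit, so no step between compound 1 and compound 4 can be read: the limit of < 4 in this assay, at which 3 of the 4 values shown sit.

The compounds shown leave open whether methoxy and isopropyl on this aromatic carbon differ at all in this assay.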